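The compounds below may be only part of what the source reports. "The series", "measured", "known", "first", "only" and "open" are said of these compounds alone.

Measured so far:
compound 1 `Nc1scc(CN2CCN(c3ccc(Cl)cc3Cl)CC2)c1C(=O)c1ccc(Cl)cc1` — 0%
compound 2 `Nc1scc(CN2CCN(c3cccc(C(F)(F)F)c3)CC2)c1C(=O)c1ccc(Cl)cc1` — 0%

In an assay on CHO cells for displacement of a labelled ligand from adenosine receptor A1 (Homo sapiens), read by scintillation counting, with a stated time of 120 min, tested at 10 uM (on this read-out lower numbers stand for less inhibition and higher numbers for more inhibition at the one concentration tested (going by the name of the read-out)), compound 1 gives 0% and compound 2 gives 0%. Among the compounds with values here, compound 1 therefore stands level with compound 2 at the digits printed; the one step, no change at the digits printed from compound 1 to compound 2 (within the scatter), shows that swapping the aryl group on the ring nitrogen between these two variants leaves the read-out unchanged within the scatter.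

Compound 3 `Nc1scc(CN2CCN(c3cccc(F)c3)CC2)c1C(=O)c1ccc(Cl)cc1` has not yet been measured in this assay. It differs from compound 1 in one place: 3-fluorophenyl in place of 2,4-dichlorophenyl on an amine nitrogen in a ring. Within the data shown here, the only step that bears on this change is the one from compound 1 to compound 2, which also exchanges the aryl group on the same ring nitrogen and is reported as no change within the scatter. On that basis no step beyond the scatter is expected in this assay; the expected step is no change at the digits printed from compound 1 to compound 3 (within the scatter).

Compound 3 is accordingly estimated at 0% in this assay, with a range from -8% to 12%.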

Compound 3, a percentage reported as inhibition, at one concentration (the size of the read-out at that concentration, not a potency): 1%
Compound 3: the middle estimate sits 1 percentage points below what was measured, within the range that was stated.
By their numbers in this assay, from the lowest: compounds 1, 2 and 3 (each within the scatter of the next).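

In this assay the change of aryl group on the amine nitrogen in a ring again shows no step beyond the scatter: 3-fluorophenyl in place of 2,4-dichlorophenyl gives a number 1 percentage points higher from compound 1 to compound 3 (within the scatter) and the series now also holds a change of one substituent on the same phenyl, since fluoro in place of trifluoromethyl on an aromatic carbon gives a number 1 percentage points higher from compound 2 to compound 3 (within the scatter) as its result. Two different replacements of the aryl group and one replacement of the substituent on it therefore all stay within the scatter, so at this position these three halogen-bearing phenyl groups cannot be told apart, and with all three values close to zero the read-out offers little room to see a loss. No measurement on hand offers an explanation for this lack of response.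

Still open, as far as these compounds go, is whether a group of another kind on the same nitrogen, such as a benzyl, a methoxyphenyl or a pyridine ring, would lift the read-out clear of the scatter. Also open, from the compounds shown here alone, is whether any change away from this position, such as an acetamide in place of the free amine on the shared core, would do so.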